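The source may report more compounds than this note shows. Statements on the series, on what has been measured and on what is new or still open speak of the compounds shown alone.

Of the compounds shown here, three sharing one core have been measured in an assay on isolated protein for displacement of a labelled ligand from metabotropic glutamate receptor 5 (Homo sapiens), with a stated time of 60 min, tested at 1 uM; a lower number here means less inhibition, a higher number more inhibition at the concentration tested (going by the name of the read-out). Compound 1 `Cc1ccc(S(=O)(=O)c2cnc3ccc(F)cc3c2N2CCC(C)CC2)cc1` gives 91%, compound 2 `CC1CCN(c2c(S(=O)(=O)c3ccc(Cl)cc3)cnc3ccc(F)cc23)CC1` gives 80%, and compound 3 `COc1cccc(S(=O)(=O)c2cnc3ccc(F)cc3c2N2CCC(C)CC2)c1` gives 90%, the second highest of the three numbers. The step to compound 4 `CC1CCN(c2c(S(=O)(=O)c3ccc(F)c(Cl)c3)cnc3ccc(F)cc23)CC1` is 3-chloro-4-fluorophenyl in place of 3-methoxyphenyl on a sulfonyl sulfur. Among the compounds with values here, two measured steps bear on the group attached to the sulfonyl sulfur: a number 1 percentage points lower from compound 1 to compound 3 (within the scatter), and a number 10 percentage points higher from compound 2 to compound 3 (within the scatter); the related step of a number 11 percentage points lower from compound 1 to compound 2 (beyond the scatter) shows that a chloro-bearing phenyl came out somewhat lower than a methyl-bearing one. Since compound 4 carries a halogenated phenyl like compound 2, whose value is 80%, a small drop, near the edge of the scatter, is expected in this assay. For compound 4 the estimate is 82%, between 70% and 92%, an expected step of a number 8 percentage points lower from compound 3 to compound 4 (within the scatter).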

Compound 4, a percentage reported as inhibition, at one concentration (the size of the read-out at that concentration, not a potency): 95%
The estimate for compound 4 lay 13 percentage points below the measured number; the measured number lies above the stated range.
By their numbers in this assay, from the lowest: compounds 2, 3, 1 and 4 (each within the scatter of the next, the first and the last beyond it).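

A chlorine on the phenyl does not by itself keep the number low in this assay: there is a number 15 percentage points higher from compound 2 to compound 4 (beyond the scatter) on changing 4-chlorophenyl to 3-chloro-4-fluorophenyl. The same group cannot be told apart from 3-methoxyphenyl or 4-methylphenyl, with a number 5 percentage points higher from compound 3 to compound 4 (within the scatter) and a number 4 percentage points higher from compound 1 to compound 4 (within the scatter) on this change at the sulfonyl sulfur. Nothing available gives a reason for these numbers. Every group shown on the sulfonyl sulfur is a substituted phenyl, so how a pyridine ring or a short alkyl chain would read there stays open.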